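The compounds below may be only part of what the source reports. "The series", "measured", "known", "first", "only" and "open" are said of these compounds alone.

Values so far in a functional assay on Bel-7402 cells (Homo sapiens) for cytotoxicity, read by MTT assay, with a stated time of 48 h (a lower number here means a stronger inhibitor, a higher number a weaker inhibitor), are these
- Compound 1 `COc1cc(-n2c(-c3ccc(O)cc3)c[nH]c2=O)cc(OC)c1OC` gives > 50000 nM (a limit, not a number)
- Compound 2 `COc1ccc(-c2cn(C(=O)Nc3cc(OC)c(OC)c(OC)c3)c(=O)n2-c2cc(OC)c(OC)c(OC)c2)cc1N` gives 10100 nM
- Compound 3 `COc1cc(-n2c(-c3ccccc3)cn(C(C)=O)c2=O)cc(OC)c1OC` gives > 50000 nM (a limit, not a number)

Compound 3 has no numerical value, and its result is only a limit of the assay. On these data alone, this is the limit of > 50000 nM in this assay, at which 2 of the 3 values shown sit, so the true strength of compound 3 remains unknown.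

Compound 4 `COc1ccc(-c2cn(C(C)=O)c(=O)n2-c2cc(OC)c(OC)c(OC)c2)cc1N` keeps the acetyl group of compound 3 but has 3-amino-4-methoxyphenyl in place of phenyl on an aromatic carbon.

Among the compounds with values here, no pair of measured compounds shows this change on its own, so any forecast rests on thin support. A step towards stronger inhibition in this assay, clearly beyond the scatter, seems likely because compound 2 10100 nM carries the same 3-amino-4-methoxyphenyl group and still gives a number. Compound 2 differs from compound 4 elsewhere, however, so compound 4 could also remain at the limit. The expected change is an at least 16-fold lower number from compound 3 to compound 4 (1.22 log units; beyond the scatter), and this size is only an estimate. For compound 4 the estimated value is 3000 nM, with an expected range from 150 nM to 40000 nM.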

Compound 4, half-maximal inhibitory concentration: 600 nM
Beside the measured number, compound 4's estimate is 5.0-fold (0.70 log units) above it, within the range that was stated.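

In this assay, putting 3-amino-4-methoxyphenyl in place of phenyl on this aromatic carbon, with the acetyl group kept, gives an at least 83-fold lower number from compound 3 to compound 4 (1.92 log units; beyond the scatter). This is the only change in a single place among the compounds shown, so it gives the first direct sign that the group at this position can carry a compound from the limit of the assay to a real number. Compound 3 gives > 50000 nM, which is a limit and not a number, so the step gives only the smallest size the change could have, because one end of it is a limit: the limit of > 50000 nM in this assay, at which 2 of the 4 values shown sit.

The amine and the methoxy group enter together, so the compounds shown cannot say how much of the step belongs to each of them. On these data alone, it also stays open what a dimethylamino group or a carboxylic acid in the place of that amine would give on the same acetyl-bearing core.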